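The compounds below may be only part of what the source reports. "The series", "measured", "known", "first", "only" and "open" are said of these compounds alone.

Three compounds sharing one core were measured in an assay on isolated protein for inhibition of steroid 17-alpha-hydroxylase/17,20 lyase (Homo sapiens); on this read-out higher numbers stand for weaker inhibition and lower numbers for stronger inhibition. Compound 1 `COc1ccc2cc([C@](O)(c3c[nH]cn3)C(C)C)ccc2c1` gives 28 nM, compound 2 `CCNC(=O)c1ccc2cc(C(O)(c3c[nH]cn3)C(C)C)ccc2c1` gives 46 nM, and compound 3 `CNC(=O)c1ccc2cc(C(O)(c3c[nH]cn3)C(C)C)ccc2c1C` gives 160 nM. Compound 2 holds the second highest number of the three: its value lies within the scatter of compound 1, while compound 3 sits beyond the scatter above it. Compound 4 `CC(C)C(O)(c1ccc2cc(C(N)=O)ccc2c1)c1c[nH]cn1` has not yet been measured in this assay. Its structure differs from compound 2 in one place: hydrogen in place of ethyl on an amide-type nitrogen. Among the measured compounds shown here, no pair of measured compounds isolates this change, so nothing here fixes its size. The step this estimate means is expected to be modest, a 1.3-fold higher number from compound 2 to compound 4 (0.12 log units; within the scatter), in no direction beyond the scatter. Compound 4 is estimated at 60 nM in this assay, ranging from 25 nM to 150 nM.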

Compound 4, half-maximal inhibitory concentration: 30 nM
Estimate against measurement, compound 4: 2.0-fold (0.30 log units) above; measured number inside the range.
By their numbers in this assay, from the lowest: compounds 1, 4 and 2 (each within the scatter of the next); then compound 3.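

In this assay, among the compounds shown here, hydrogen in place of ethyl on an amide-type nitrogen gives a 1.5-fold lower number from compound 2 to compound 4 (0.19 log units; within the scatter), the first reading of this change, and it leaves ethylcarbamoyl and carbamoyl unseparated on this read-out. At this position, then, the ethyl group is not needed to hold a number of this size, at least for this pair alone. Nothing measured here bears on why the two compounds read alike. As far as these compounds go, whether a longer chain such as butyl on this nitrogen would read the same stays open. So does a carboxylic acid in place of the carbamoyl group.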